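Nitro to hydrogen on compound 2

A few compounds are considered here, and "the series" means these few. Any claim that something is new, unique, unknown or untested is made for them only; others in the source may bear on it.

Measured so far in an ADME assay for permeability, using PAMPA (on this read-out higher numbers stand for higher permeability and lower numbers for lower permeability), for this series
compound 1 `Cc1ccc(O)c(C(=O)Nc2ccc([N+](=O)[O-])cc2Cl)c1` gives 134 10^-6 cm/s
compound 2 `O=C(Nc1c(Cl)cc([N+](=O)[O-])cc1Cl)c1cc(Cl)ccc1O` gives 53 10^-6 cm/s
compound 3 `O=C(Nc1ccccc1C(F)(F)F)c1cc(Cl)ccc1O` gives 26 10^-6 cm/s

Compound 2 stands second of these three numbers, beyond the scatter from both compound 1 and compound 3. Going to compound 4 `O=C(Nc1c(Cl)cccc1Cl)c1cc(Cl)ccc1O` puts hydrogen in place of nitro on an aromatic carbon and leaves the rest of compound 2 unchanged. For the measured compounds named here, no measured pair isolates this change. Compound 3 also carries no nitro and gives 26 10^-6 cm/s as its number, but it differs elsewhere too, so it is only a weak guide. A small fall in this assay is expected, possibly none beyond the scatter. The estimated step is a 1.3-fold lower number from compound 2 to compound 4 (0.12 log units; within the scatter) on this basis. Compound 4 is expected at 40 10^-6 cm/s (estimated range 16 10^-6 cm/s to 100 10^-6 cm/s).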

Compound 4, apparent permeability in the ADME assay: 73 10^-6 cm/s
Beside the measured number, compound 4's estimate is 1.8-fold (0.26 log units) below it; low and high end bracket the measured number.
By their numbers in the ADME assay, from the lowest: compound 3; then compounds 2, 4 and 1 (each within the scatter of the next, the first and the last beyond it).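

For the compounds shown here, in the ADME assay, the first pair to isolate this position, hydrogen in place of nitro on an aromatic carbon gives a 1.4-fold higher number from compound 2 to compound 4 (0.14 log units; within the scatter), so this read-out does not separate nitro from hydrogen here. The same change does separate the pair in a physicochemical assay for solubility (a lower number here means a less soluble compound, a higher number a more soluble compound), beyond the scatter: the measured solubility of compound 2, 53 ug/mL, and of compound 4, 21 ug/mL, a 2.5-fold lower number (0.40 log units; beyond the scatter) In the physicochemical assay compound 2 gives 53 ug/mL and compound 4 gives 21 ug/mL.

The compounds shown compare only nitro and hydrogen at this position, so an amine or a carboxylic acid there remains open on both read-outs. On these data alone, with a single pair, it also remains open whether the change behaves alike on the core of compound 1.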